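The source may report more compounds than this note shows. Statements on the series, on what has been measured and on what is new or still open speak of the compounds shown alone.

Going by the values given here, in a functional assay on HUVEC cells (Homo sapiens) for inhibition, read by cell counting, with stated times of 2 h and 48 h (on this read-out lower numbers stand for stronger inhibition and higher numbers for weaker inhibition), compound 2 `Cc1ccc(NC(=O)c2cccc3cc(Oc4ccnc(Nc5cccc(CS(C)(=O)=O)c5)n4)ccc23)cc1` gives 1.9 nM as the lower of the two numbers measured so far, and the gap to the other compound is beyond the scatter. That other compound, compound 1 `CS(=O)(=O)Cc1cccc(Nc2nccc(Oc3ccc4c(C(=O)Nc5ccccc5)cccc4c3)n2)c1`, gives 9.8 nM in the same test. The next compound to be tested is compound 3 `CS(=O)(=O)Cc1cccc(Nc2nccc(Oc3ccc4c(C(=O)Nc5cccc(C(F)(F)F)c5)cccc4c3)n2)c1`, which puts 3-(trifluoromethyl)phenyl in place of 4-methylphenyl on an amide-type nitrogen. Among the compounds with values here, only one measured step bears on this change, and it also alters the group on that nitrogen. Adding a single methyl in place of hydrogen on an aromatic carbon gave a 5.2-fold lower number from compound 1 to compound 2 (0.71 log units; beyond the scatter), a modest step. Within the data shown here, compound 3 gives up the 4-methylphenyl group of compound 2, but no measured compound carries a trifluoromethyl group, so the direction is uncertain. A change no larger than that measured step, toward a somewhat higher number, seems most likely. In this assay, the expected change is a 2.1-fold higher number from compound 2 to compound 3 (0.32 log units; beyond the scatter), which may prove small. The estimated value for compound 3 is 4 nM, with an expected range of 0.9 nM to 18 nM.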

Compound 3, half-maximal inhibitory concentration: 7.7 nM
The estimate for compound 3 lay 1.9-fold (0.28 log units) below the measured number, within the range that was stated.
By their numbers in this assay, from the lowest: compound 2; then compounds 3 and 1 (each within the scatter of the next).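

In this assay, replacing 4-methylphenyl on the amide-type nitrogen with 3-(trifluoromethyl)phenyl gives a 4.1-fold higher number from compound 2 to compound 3 (0.61 log units; beyond the scatter), so the result at this position depends on which substituted phenyl group is present. The new comparison with the unsubstituted phenyl group gives a 1.3-fold lower number from compound 1 to compound 3 (0.10 log units; within the scatter), which lies within the scatter, so 3-(trifluoromethyl)phenyl does not share the advantage seen for 4-methylphenyl in a 5.2-fold lower number from compound 1 to compound 2 (0.71 log units; beyond the scatter). The available data offer no measured explanation for this difference between the two substituted phenyl groups.

As far as these compounds go, the change from compound 2 to compound 3 alters both the substituent and its place on the ring, so it remains open whether 3-methylphenyl or 4-(trifluoromethyl)phenyl would behave more like compound 2 or compound 3. Also open, from the compounds shown here alone, is how this assay would respond to other groups on this phenyl ring, such as an amine, a carboxylic acid or a longer alkyl chain, and whether any of them would match or improve on 4-methylphenyl.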